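The source may report more compounds than this note shows. Statements on the series, on what has been measured and on what is new or still open speak of the compounds shown alone.

Values in an ADME assay on Vero cells (Chlorocebus sabaeus) for cytotoxicity, read by MTT assay, with a stated time of 72 h; on this read-out higher numbers stand for lower toxicity in this test and lower numbers for higher toxicity in this test:
- compound 1 `COc1c(N2CCN(CC#N)C(C)C2)c(F)cc2c(=O)c(C(=O)O)cn(C3CC3)c12`: 354 ug/mL
- compound 2 `COc1c(N2CCN(CCC(C)=O)C(C)C2)c(F)cc2c(=O)c(C(=O)O)cn(C3CC3)c12`: 9.84 ug/mL
- compound 3 `CO/N=C(\C)CN1CCN(c2c(F)cc3c(=O)c(C(=O)O)cn(C4CC4)c3c2OC)CC1C`: 49.6 ug/mL

Among the three numbers, compound 3 at 49.6 ug/mL is second highest. The next change leads to compound 4 `COc1c(N2CCN(C/C(C)=N/NC(C)=O)C(C)C2)c(F)cc2c(=O)c(C(=O)O)cn(C3CC3)c12`, with acetamido in place of methoxy on a double-bonded nitrogen. The nearest evidence in this assay is a 5.0-fold higher number from compound 2 to compound 3 (0.70 log units; beyond the scatter), together with a 7.1-fold lower number from compound 1 to compound 3 (0.85 log units; beyond the scatter) and a 36-fold lower number from compound 1 to compound 2 (1.56 log units; beyond the scatter). All three are beyond the scatter, so this part of the structure can move the number. None of them varies the group on the double-bonded nitrogen, however, so they give no direction. The expected outcome is a 1.2-fold lower number from compound 3 to compound 4 (0.09 log units; within the scatter), with no step beyond the scatter anticipated. Compound 4 is estimated at 40 ug/mL, with an expected range of 12 ug/mL to 130 ug/mL.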

Compound 4, half-maximal cytotoxic concentration: 707 ug/mL
The estimate for compound 4 lay 18-fold (1.25 log units) below the measured number; measured number above the stated range.
By their numbers in this assay, from the lowest: compound 2; then compound 3; then compounds 1 and 4 (each within the scatter of the next).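

In this assay the step of a 14-fold higher number from compound 3 to compound 4 (1.15 log units; beyond the scatter) shows that the group on the double-bonded nitrogen, and not only the chain as a whole, can move the number. The step of a 72-fold higher number from compound 2 to compound 4 (1.86 log units; beyond the scatter) also lies beyond the scatter, whereas a 2.0-fold higher number from compound 1 to compound 4 (0.30 log units; within the scatter) lies within it, so compound 4 and compound 1 cannot be told apart in this test. No available evidence bears on what lies behind this change.

Still open, on these data alone, is how an amino group or a longer acylamino chain on the double-bonded nitrogen would compare with acetamido.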